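Thiophen-2-yl for phenyl on two nucleoside cores: notes

This account rests on a few compounds, and the source may have more. Where it says the series, first, only, none or still open, it means among the compounds named here.

Measured so far in an ADME assay on MRC5 cells (Homo sapiens), read by MTT assay, with a stated time of 72 h; on this read-out higher numbers stand for weaker inhibition and lower numbers for stronger inhibition:
compound 1 `COc1ncnc2c1c(-c1cccs1)cn2[C@@H]1O[C@H](CO)[C@@H](O)[C@H]1O` gives 43200 nM
compound 2 `Nc1nc(N)c2c(-c3ccccc3)cn([C@@H]3O[C@H](CO)[C@@H](O)[C@H]3O)c2n1` gives > 100000 nM, which is a limit of the assay and not a number
compound 3 `COc1ncnc2c1c(-c1ccccc1)cn2[C@@H]1O[C@H](CO)[C@@H](O)[C@H]1O` gives > 100000 nM, which is also a limit of the assay and not a number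

Compound 3 and compound 1 share one core and differ in a single place: thiophen-2-yl in place of phenyl on an aromatic carbon. This change produced an at least 2.3-fold lower number from compound 3 to compound 1 (0.36 log units; beyond the scatter). The size of that step is itself only a bound, because compound 3 sits at the limit of > 100000 nM in this assay, at which 2 of the 3 values shown sit.

Compound 4 `Nc1nc(N)c2c(-c3cccs3)cn([C@@H]3O[C@H](CO)[C@@H](O)[C@H]3O)c2n1` has not been measured in this assay. It differs from compound 2 in exactly the same way: thiophen-2-yl in place of phenyl on an aromatic carbon. The surroundings of the change are described in identical words for both pairs, so this is the same change made on a second core. How the core of compound 2 differs from the core of compound 3 is not broken down here.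

For compound 2 only a limit of the assay is known in this assay. Going by the values given here, the expected step from compound 2 to compound 4 is an at least 1.6-fold lower number from compound 2 to compound 4 (0.22 log units; that floor lies within the scatter), resting on an at least 2.3-fold lower number from compound 3 to compound 1 (0.36 log units; beyond the scatter) as the one measured instance of this change. Compound 4 is therefore expected to give about 60000 nM in this assay, with a range from 25000 nM to 200000 nM. There is a fair chance that compound 4 is again reported only as a limit.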

Compound 4, half-maximal inhibitory concentration: > 100000 nM
Compound 4 gave a limit, no number; the forecaster's own chance of this, stated with the estimate: 50%; middle value at least 1.6-fold (0.22 log units) away from the limit.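

Compound 2 and compound 4 both stand only as limits of the assay in this assay, so no step for thiophen-2-yl in place of phenyl can be read on this core: the limit of > 100000 nM in this assay, at which 3 of the 4 values shown sit.

From the compounds shown here alone, whether this change lowers the number on the core of compound 2, as it does between compound 3 and compound 1, and by how much, stays open.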